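Adding 4-Chlorophenyl to a Compound Tolerated Up to the Limit

A few compounds are considered here, and "the series" means these few. Any claim that something is new, unique, unknown or untested is made for them only; others in the source may bear on it.

Compound 1 `CCS(=O)(=O)N1CCC2(CC1)OOC1(CCCC1)OO2`: > 100 ug/mL, a limit
Compound 2 `CCS(=O)(=O)N1CCC2(CC1)OOC1(CCCCCC1)OO2`: > 100 ug/mL, a limit
Compound 3 `CCCS(=O)(=O)N1CCC2(CC1)OOC(C)(C)OO2`: > 100 ug/mL, a limit

In a functional assay on Huh-7 cells (Homo sapiens) for cytotoxicity, read by MTT assay, with a stated time of 72 h (a lower number here means that less compound is tolerated, a higher number that more compound is tolerated), compound 3 gives > 100 ug/mL, which is a limit and not a number. It shares this position with the other two compounds, as the limit of > 100 ug/mL in this assay, at which 3 of the 3 values shown sit, shows. Compound 4 `CCCS(=O)(=O)N1CCC2(CC1)OOC(C)(c1ccc(Cl)cc1)OO2` carries 4-chlorophenyl in place of methyl on a saturated ring carbon, a change counted as 4-chlorophenyl in place of methyl on a saturated ring carbon. Among the compounds with values here, no measured step shows what such a swap does, and none of the measured compounds carries an aromatic ring. A modest shift toward less compound tolerated is expected, and the estimated size is an at least 1.6-fold lower number from compound 3 to compound 4 (0.22 log units; that floor lies within the scatter). In this assay the estimate for compound 4 is 60 ug/mL, with an expected range from 20 ug/mL to 100 ug/mL.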

Compound 4, half-maximal cytotoxic concentration: > 100 ug/mL
Compound 4: only a limit was reported; the forecaster's own chance of this, stated with the estimate: 50%; middle value at least 1.6-fold (0.22 log units) away from the limit.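

Within the data shown here, compound 3 and compound 4 are both reported only as limits, so no step between them can be read: the limit of > 100 ug/mL in this assay, at which 4 of the 4 values shown sit. What 4-chlorophenyl in place of methyl does to tolerated concentration stays open, as does the concentration at which any of these compounds becomes toxic to the cells.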